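Cyclohexyl for 4-chlorophenyl on a carbonyl carbon

The compounds below may be only part of what the source reports. "The series", "measured", "known", "first", "only" and "open" are said of these compounds alone.

Values in a toxicity assay on THP-1 cells (Homo sapiens) for inhibition; a higher number here means that more compound is tolerated, a lower number that less compound is tolerated (both are limits):
Compound 1 `Cc1ccccc1-c1cnc(NC(=O)c2ccc(F)cc2)n1C` gives > 50000 nM as a limit
Compound 2 `Cn1c(-c2ccccc2)cnc1NC(=O)c1ccc(Cl)cc1` gives > 100000 nM as a limit

Compound 2 stands at > 100000 nM as a limit of this assay and not as a number. Compound 1 likewise gives > 50000 nM as a limit. For the measured compounds named here, neither measured compound offers a number, and no single-place step connects them.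

Compound 3 `Cn1c(-c2ccccc2)cnc1NC(=O)C1CCCCC1` carries cyclohexyl in place of 4-chlorophenyl on a carbonyl carbon, and the change counts out as cyclohexyl in place of 4-chlorophenyl on a carbonyl carbon with the rest of the structure unchanged.

Going by the values given here, with no measured step to draw on, the change expected in this assay is none beyond the scatter, in either direction. The estimated move is a number no higher from compound 2 to compound 3 (the limit leaves the size open) and it remains only an expectation. This expectation rests on compound 2, whose > 100000 nM is a limit, and another limit reading would be no surprise. The estimated value of compound 3 is 100000 nM with 40000 nM as the lower end and 250000 nM as the upper end of the expected range.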

Compound 3, half-maximal cytotoxic concentration: > 100000 nM
Compound 3: no number, only a limit (the forecaster's own chance of this, stated with the estimate: 80%); the middle value sits exactly at the limit.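

In this assay compound 3 gives > 100000 nM, which is a limit and not a number. Compound 2 also stands only as a limit, and the step from compound 2 to compound 3 cannot be read. The compounds shown leave open the concentration at which any of them reaches half-maximal cytotoxicity, and whether cyclohexyl and 4-chlorophenyl differ there.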